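Compound 1 to compound 4: chloro removed from the nitro ring

The compounds below may be only part of what the source reports. "The series", "measured", "known", "first", "only" and "open" are said of these compounds alone.

Of the compounds shown here, three have been measured: compound 1 `O=[N+]([O-])c1cc(Cl)ccc1CNc1cc(C(F)(F)F)cc2[nH]ncc12`, compound 2 `O=C(O)c1cccc(CNc2cc(C(F)(F)F)cc3[nH]ncc23)c1` and compound 3 `FC(F)(F)c1cc(NC[C@@H]2CCCCN2)c2cn[nH]c2c1`. In an assay for inhibition of Indoleamine 2,3-dioxygenase 1 (Homo sapiens), with stated times of 10 min and 60 min, tested at 100 uM (a lower number here means a weaker effect, a higher number a stronger effect of the compound at the concentration tested), compound 1 gives 77%, the second highest of the three numbers. Compound 3 gives 81%, which lies within the scatter of compound 1, so no order between the two is drawn. Compound 2 gives 17%, a number well below compound 1 and beyond the scatter. Compound 4 `O=[N+]([O-])c1ccccc1CNc1cc(C(F)(F)F)cc2[nH]ncc12` has not been measured; it differs from compound 1 by hydrogen in place of chloro on an aromatic carbon. Among the measured compounds shown here, no measured pair shows the effect of such a change. The expected step is a number 7 percentage points lower from compound 1 to compound 4 (within the scatter), slightly downward and not beyond the scatter. Compound 4 is estimated at 70%, with a range from 50% to 85%.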

Compound 4, a percentage reported as inhibition, at one concentration (the size of the read-out at that concentration, not a potency): 76%
Compound 4: the middle estimate sits 6 percentage points below what was measured; measured number inside the range.
By their numbers in this assay, from the lowest: compound 2; then compounds 4, 1 and 3 (each within the scatter of the next).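

Hydrogen in place of chloro, meta to the nitro group and para to the large group, gives in this assay a number 1 percentage points lower from compound 1 to compound 4 (within the scatter) and so no readable change. At this single concentration, the chloro at this carbon is therefore not required for the read-out. No measured evidence bears on this result.

Still open, going by these compounds, is whether a larger or different group on this carbon, such as methoxy or bromo, would move the number beyond the scatter. Also open, on these data alone, is how the nitro group contributes, and single-concentration numbers leave potency unread.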